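The source may hold more compounds than are shown below. What is called first, only, known or untested is meant among the compounds shown, and "the series" means these compounds.

Measured in a functional assay on SW480 cells (Homo sapiens) for antiproliferative activity, read by MTT assay, with a stated time of 48 h; a lower number here means a stronger inhibitor, a higher number a weaker inhibitor:
Compound 1 `CCC(CCO)n1cnc2c(Cl)ncnc21`: > 50000 nM (a limit)
Compound 2 `CCCCCC(CCO)n1cnc2c(Cl)ncnc21`: > 50000 nM (a limit)
Compound 3 `CCCCCCC(CCO)n1cnc2c(Cl)ncnc21`: 16700 nM

In this assay, among the measured compounds shown here, compound 3 gives 16700 nM, the only true number in this small set. The remaining results are not numbers: the limit of > 50000 nM in this assay, at which 2 of the 3 values shown sit. The step that the two limits leave unreadable from compound 1 to compound 2 therefore cannot be sized.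

The next compound, compound 4 `CCCCCCC(CCO)n1cnc2c(N)ncnc21`, keeps the chain of compound 3 and changes the core: amino in place of chloro on an aromatic carbon. The readable steps are an at least 2.9-fold lower number from compound 1 to compound 3 (0.47 log units; beyond the scatter) and an at least 2.9-fold lower number from compound 2 to compound 3 (0.47 log units; beyond the scatter). For the measured compounds named here, both are changes on the chain, and all three measured compounds carry the chloro, so no measured step speaks directly to this swap. Going by the values given here, they show only that compound 3 is the one compound here to give a number, and that this number depends on the chain.

With no direct measurement of the swap, a modest move to a higher number is expected, and a result reported only as a limit would be no surprise. The step expected is a 2.3-fold higher number from compound 3 to compound 4 (0.36 log units; beyond the scatter). For compound 4 the estimated value is 38000 nM, with an expected range from 14000 nM to 50000 nM.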

Compound 4, half-maximal inhibitory concentration: > 50000 nM
Compound 4: a limit, no number; the forecaster's own chance of this, stated with the estimate: 50%; at least 1.3-fold (0.11 log units) between middle value and limit.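

In this assay, among the compounds shown here, amino in place of chloro on an aromatic carbon gives an at least 2.9-fold higher number from compound 3 to compound 4 (0.47 log units; beyond the scatter), the first reading at this position of the core. For the compounds shown here, all the earlier steps lay on the chain and all three earlier compounds carried the chloro, so they showed only that the number of compound 3 depends on the chain; this step shows that, with this chain, it depends on the group at this position as well. Compound 4 is reported only as a limit, not a number, so the step has a lower bound and no measured size, and the set as a whole now reads: the limit of > 50000 nM in this assay, at which 3 of the 4 values shown sit.

The compounds shown do not tell whether the chloro itself is needed at this position, or whether another group, such as bromo, methoxy or methylamino, would also give a number. They also leave open whether a longer chain would give a number with the amino in place, or whether the same swap would then give a step of a different size.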